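Swapping fluoro for methoxy on an aromatic ring

A few compounds are considered here, and "the series" means these few. Any claim that something is new, unique, unknown or untested is made for them only; others in the source may bear on it.

In a functional assay on A2780 cells (Homo sapiens) for inhibition, with a stated time of 72 h (a higher number here means a weaker inhibitor, a lower number a stronger inhibitor), compound 1 `CC(=O)O[C@@]1([C@@H]2/C(C)=C(/O)C(=O)C3=C(C)[C@@H](OC(=O)[C@H](O)[C@H](C=C(C)C)NC(=O)OC(C)(C)C)C[C@@](O)([C@H]2OC(=O)c2cccc(Cl)c2)C3(C)C)CO[C@@H]1CCO` gives 1.7 nM, compound 2 `CC(=O)O[C@@]1([C@@H]2/C(C)=C(/O)C(=O)C3=C(C)[C@@H](OC(=O)[C@H](O)[C@H](CC(C)C)NC(=O)OC(C)(C)C)C[C@@](O)([C@H]2OC(=O)c2cccc(F)c2)C3(C)C)CO[C@@H]1CCO` gives 12.8 nM, and compound 3 `CC(=O)O[C@@]1([C@@H]2/C(C)=C(/O)C(=O)C3=C(C)[C@@H](OC(=O)[C@H](O)[C@H](C=C(C)C)NC(=O)OC(C)(C)C)C[C@@](O)([C@H]2OC(=O)c2cccc(F)c2)C3(C)C)CO[C@@H]1CCO` gives 6.9 nM. Compound 3 stands clearly apart only from compound 1. The remaining step is a 1.9-fold lower number from compound 2 to compound 3 (0.27 log units; within the scatter), which lies within the scatter, so those two cannot be told apart.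

Compound 4 `COc1cccc(C(=O)O[C@H]2[C@H]([C@]3(OC(C)=O)CO[C@@H]3CCO)/C(C)=C(/O)C(=O)C3=C(C)[C@@H](OC(=O)[C@H](O)[C@H](C=C(C)C)NC(=O)OC(C)(C)C)C[C@]2(O)C3(C)C)c1` keeps all of compound 3 except for one group: methoxy in place of fluoro on an aromatic carbon. In words, methoxy takes the place of fluoro on an aromatic carbon, meta to a large group.

Going by the values given here, only one measured step touches this spot. It is a 4.1-fold higher number from compound 1 to compound 3 (0.61 log units; beyond the scatter), a modest change beyond the scatter, and it shows that the number in this assay can respond to the group held there. The step involving compound 2 lies elsewhere in the molecule and says little about this swap. Among the compounds with values here, no methoxy compound has been measured, so the direction is only a lean, based on compound 1 at 1.7 nM, where a group other than fluoro gave the lower number. The expected step is small, no larger than the one seen at this spot, and is estimated as a 1.9-fold lower number from compound 3 to compound 4 (0.28 log units; within the scatter). Compound 4 is estimated at 3.6 nM, with an expected range of 1.3 nM to 10 nM.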

Compound 4, half-maximal inhibitory concentration: 2.6 nM
Beside the measured number, compound 4's estimate is 1.4-fold (0.14 log units) above it; measured number inside the range.
By their numbers in this assay, from the lowest: compounds 1 and 4 (each within the scatter of the next); then compounds 3 and 2 (each within the scatter of the next).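

In this assay, going by these compounds alone, the earlier compounds showed only that chloro and fluoro at this place on the aromatic ring could give different numbers; methoxy now gives a second change from fluoro, with a 2.7-fold lower number from compound 3 to compound 4 (0.42 log units; beyond the scatter) and a result beyond the scatter. This change runs in the same direction as the one from fluoro to chloro, so the fluoro of compound 3 stands apart from both other groups tested here, with the higher number. Set against chloro, methoxy gives a 1.5-fold higher number from compound 1 to compound 4 (0.18 log units; within the scatter) and so cannot be told apart from it, even though the two groups differ in their atoms; no supporting information is available to explain why fluoro stands apart.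

The compounds shown hold only chloro, fluoro and methoxy at this place, so it remains open how the number would respond to a hydroxyl, an amine, a carboxylic acid or a longer chain such as ethoxy. As far as these compounds go, it also remains open whether the step from fluoro to methoxy would carry over to compound 2, which has isobutyl where compound 3 has 2-methylprop-1-en-1-yl.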